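Methyl ester of the saturated acid: expected potency

The source may report more compounds than this note shows. Statements on the series, on what has been measured and on what is new or still open speak of the compounds shown alone.

Three members of this series share one core, shown in compound 1 `O=C(O)COc1ccncc1-c1ccc2ccccc2c1`, a carboxymethoxy analogue for which no result was determined: in an assay on a protein complex for inhibition of CDK8/Cyclin C (Homo sapiens), with a stated time of 1 h (on this read-out lower numbers stand for stronger inhibition and higher numbers for weaker inhibition), compound 1 gives "not determined" (no result reported). In this assay compound 2 `COC(=O)/C=C/c1ccncc1-c1ccc2ccccc2c1` gives 40.6 nM, and compound 3 `O=C(O)CCc1ccncc1-c1ccc2ccccc2c1` gives 50.5 nM. Among the compounds with values here, compound 3 therefore holds the higher of the two numbers available, but the only measured step, a 1.2-fold higher number from compound 2 to compound 3 (0.09 log units; within the scatter), is within the scatter, so no ordering between them can be claimed.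

Compound 4 `COC(=O)CCc1ccncc1-c1ccc2ccccc2c1` differs from compound 3 by methyl in place of hydrogen on an oxygen next to a carbonyl group. Within the data shown here, the single measured step bearing on this change, from compound 2 to compound 3, swapped an ester for an acid together with a change in the connecting chain and stayed within the scatter. On that basis the expected step of a 1.1-fold lower number from compound 3 to compound 4 (0.05 log units; within the scatter) is small, with no direction beyond the scatter. Compound 4 is therefore estimated to give 45 nM in this assay, within a range from 18 nM to 110 nM.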

Compound 4, half-maximal inhibitory concentration: 259 nM
Estimate against measurement, compound 4: 5.8-fold (0.76 log units) below; measured number outside the range, above it.
By their numbers in this assay, from the lowest: compounds 2 and 3 (each within the scatter of the next); then compound 4.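

In this assay, turning the acid into its methyl ester costs activity at this oxygen, with a 5.1-fold higher number from compound 3 to compound 4 (0.71 log units; beyond the scatter), and with the methyl ester held constant, replacing 2-(methoxycarbonyl)ethenyl by 2-(methoxycarbonyl)ethyl also costs activity, with a 6.4-fold higher number from compound 2 to compound 4 (0.80 log units; beyond the scatter). The closeness of compound 2 and compound 3, which differ in both the ester and the chain, therefore did not mean that these features were unimportant, since each change made alone moves the number beyond the scatter. Nothing shown here explains why either change weakens inhibition.

On these data alone, it remains open how 2-carboxyethenyl, the acid that carries the unsaturated chain, would compare with these compounds. An amide in place of the ester, or a longer chain ending in a carboxylic acid, is also left untested by the compounds shown.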